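The source may report more compounds than this note shows. Statements on the series, on what has been measured and on what is new or still open speak of the compounds shown alone.

Compound 1, `CC(=O)OC[C@H]1O[C@H](OC[C@H](Cn2cc(-c3ccc(-c4noc(NC5CCCCC5)n4)cc3)nn2)OC(C)=O)C=C[C@@H]1OC(C)=O`, in an ADME assay on HepG2 cells (Homo sapiens) for cytotoxicity, read by MTT assay, with a stated time of 48 h (a higher number here means that more compound is tolerated, a lower number that less compound is tolerated), gives 79.8 ug/mL.
Compound 2, `C#CCN(c1nc(-c2ccc(Cl)cc2)no1)C1CCCCC1`, in this assay gives 41.3 ug/mL.
Compound 3, `CC(=O)OC[C@H]1O[C@H](OC[C@@H](Cn2cc(CN(c3nc(-c4ccc(C)cc4)no3)C3CCCCC3)nn2)OC(C)=O)C=C[C@@H]1OC(C)=O`, in this assay gives 36.8 ug/mL.

Of these three numbers, compound 2 holds the second highest. Its nearest neighbour is compound 3, whose value lies within the usual scatter of compound 2, so the two cannot be told apart. The furthest is compound 1, and even that gap stays within the scatter, so all three measured compounds are, in effect, tolerated to a similar degree on these cells.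

Compound 4, `C#CCN(c1nc(-c2ccc(Br)cc2)no1)C1CCCCC1`, differs from compound 2 in one place: bromo in place of chloro on an aromatic carbon. For the measured compounds named here, no step between two measured compounds has been recorded, so there is nothing to calibrate this exchange against. With one atom swapped for one atom at the same place, and no change in ring count, donors, acceptors or charge, the step is expected to be none beyond the scatter, in no particular direction. The step this expectation means, a 1.0-fold lower number from compound 2 to compound 4 (0.01 log units; within the scatter), is expected to fall inside the scatter. Compound 4 is therefore estimated at 40 ug/mL, with a range from 20 ug/mL to 80 ug/mL.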

Compound 4, half-maximal cytotoxic concentration: 102 ug/mL
Estimate against measurement, compound 4: 2.6-fold (0.41 log units) below, outside the stated range (above it).
By their numbers in this assay, from the lowest: compounds 3, 2, 1 and 4 (each within the scatter of the next, the first and the last beyond it).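

Until now, no single exchange could be read in this assay, so nothing showed whether this place on the molecule affected the number at all. Going from 4-chlorophenyl to 4-bromophenyl gives a 2.5-fold higher number from compound 2 to compound 4 (0.39 log units; beyond the scatter), so here the swap of one halogen atom for another, with ring count, donors, acceptors and charge all unchanged, is enough to produce a modest but real step. Nothing measured here accounts for the step or its direction.

This single pair cannot show whether fluoro, methoxy or an amine on the same aromatic carbon would move the number further, or in which direction. On these data alone, it also remains open whether bromo in place of chloro would give a similar step on a different core.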